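This account rests on a few compounds, and the source may have more. Where it says the series, first, only, none or still open, it means among the compounds named here.

Of the compounds shown here, three sharing one core have been tested in an ADME assay on HEK293 cells (Homo sapiens) for cytotoxicity, read by reporter gene assay and resazurin assay, with a stated time of 48 h; a higher number here means that more compound is tolerated, a lower number that less compound is tolerated. Compound 1 `COc1ccc(Br)cc1C(=O)Nc1ccc(Sc2nc3ccccc3s2)cc1` gives only a limit of the assay, > 100000 nM. Compound 3 `COc1ccccc1C(=O)Nc1ccc(Sc2nc3ccccc3s2)cc1` likewise gives only a limit, > 100000 nM. Compound 2 `O=C(Nc1ccc(Sc2nc3ccccc3s2)cc1)c1cc(Br)ccc1O` gives a number, 42000 nM, so compound 3 stands with compound 1 at the limit of > 100000 nM in this assay, at which 2 of the 3 values shown sit, not a measured number. The next compound is compound 4 `O=C(Nc1ccc(Sc2nc3ccccc3s2)cc1)c1cc(Br)cc(Br)c1`, where (3,5-dibromophenyl in place of 2-methoxyphenyl on a carbonyl carbon). For the measured compounds named here, two measured steps touch compound 3: an at least 2.3-fold higher number from compound 2 to compound 3 (0.37 log units; beyond the scatter), and a step that the two limits leave unreadable from compound 1 to compound 3. Neither covers a change to a 3,5-dibromophenyl group, so the expectation is loosely held: compound 4 is expected to stay near the limit, with no step beyond the scatter, a number no higher from compound 3 to compound 4 (the limit leaves the size open). The estimate for compound 4 is 100000 nM, between 30000 nM and 300000 nM.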

Compound 4, half-maximal cytotoxic concentration: > 100000 nM
Compound 4 was reported as a limit; the forecaster's own chance of this, stated with the estimate: 55%; the middle value sits exactly at the limit.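

In this assay, the 3,5-dibromophenyl group on the carbonyl carbon leaves compound 4 at a limit rather than a number: the limit of > 100000 nM in this assay, at which 3 of the 4 values shown sit.

Compound 4 has two bromines on this ring and no oxygen, yet the data show an at least 2.3-fold higher number from compound 2 to compound 4 (0.37 log units; beyond the scatter), so bromine alone does not bring the lower number seen with compound 2. The steps among compound 1, compound 3 and compound 4 each join two limits and cannot be read.

Going by these compounds, how much compound these three tolerate beyond the limit stays open. So does whether an amine or a carboxylic acid on this ring would give a measured number.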